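The source may hold more compounds than are shown below. What is called first, only, known or untested is meant among the compounds shown, and "the series" means these compounds.

Measured so far:
Compound 1 `Cc1nc(N(C)C(=O)NC(=O)c2c(F)cccc2F)sc1C(=O)N/N=C/c1ccccc1Cl`: > 100 ug/mL
Compound 2 `CN(C(=O)NC(=O)c1ccc(F)c(F)c1)c1nc(C(F)(F)F)c(C(=O)N/N=C/c2ccccc2C(F)(F)F)s1`: 10.4 ug/mL

Both compounds were run in a functional assay on HepG2 cells (Homo sapiens) for inhibition, read by MTT assay, with a stated time of 72 h; a lower number here means a stronger inhibitor, a higher number a weaker inhibitor. Compound 1 gives > 100 ug/mL, which is a limit of the assay and not a measured number, so its true potency is only bounded, as shown by the limit of > 100 ug/mL in this assay, at which 1 of the 2 values shown sits. Compound 2 gives 10.4 ug/mL in this assay. These two compounds differ in several places at once, so their values show only that one is a bounded limit and the other a number.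

Compound 3 `COc1ccc(/C=N/NC(=O)c2sc(N(C)C(=O)NC(=O)c3c(F)cccc3F)nc2C)cc1` differs from compound 1 in one place: 4-methoxyphenyl in place of 2-chlorophenyl on a carbon with a double bond to nitrogen. For the measured compounds named here, no measured step of this kind is available here, so the size of the change in this assay cannot be read from the data, and an expectation of no move beyond the usual scatter, in either direction, is the plainest one. Compound 3 is therefore expected at 100 ug/mL, within a range from 30 ug/mL to 300 ug/mL. The expected step from compound 1 to compound 3 is a number no higher from compound 1 to compound 3 (the limit leaves the size open).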

Compound 3, half-maximal inhibitory concentration: 22.7 ug/mL
Beside the measured number, compound 3's estimate is 4.4-fold (0.64 log units) above it; the measured number lies below the stated range.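

Placing 4-methoxyphenyl in place of 2-chlorophenyl on a carbon with a double bond to nitrogen gives an at least 4.4-fold lower number from compound 1 to compound 3 (0.64 log units; beyond the scatter) in this assay. For the compounds shown here, this is the only comparison so far that changes a single place, so it shows that the group at this position can alter the read-out, something compounds 1 and 2 could not show because they differ in several places at once. The true size of the step remains unknown because compound 1 sits at a limit of the assay and not at a measured number: the limit of > 100 ug/mL in this assay, at which 1 of the 3 values shown sits.

The compounds shown do not separate the effect of removing 2-chlorophenyl from that of adding 4-methoxyphenyl. Going by these compounds, a plain phenyl, 4-chlorophenyl or 2-methoxyphenyl on the same carbon would help to separate them, and whether an amine-bearing ring would fit this trend also remains open.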